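Amine replacement on the shared core: compound 2 to compound 3

The source may hold more compounds than are shown below. What is called first, only, known or untested is meant among the compounds shown, and "the series" means these compounds.

Compound 1 `Cn1ccc2cc(-c3ccc4oc(NC5CCCCC5)nc4c3)ccc21` gives 911 nM in an assay on HEK293 cells for inhibition of Fatty-acid amide hydrolase 1 (Homo sapiens), read by fluorescence; a higher number here means a weaker inhibitor, a lower number a stronger inhibitor. Compound 2 `Cn1ccc2cc(-c3ccc4oc(N5CCCC5)nc4c3)ccc21` gives 674 nM in this assay, and its number and that of compound 1 lie within the scatter of each other, as the step of a 1.4-fold lower number from compound 1 to compound 2 (0.13 log units; within the scatter) shows. Compound 3 `Cn1ccc2cc(-c3ccc4oc(N5Cc6cccnc6C5)nc4c3)ccc21` carries a group of 9 heavy atoms (7 carbon, 2 nitrogen; one five-membered non-aromatic ring with 1 hetero atom, one six-membered aromatic ring with 1 hetero atom) in place of a group of 5 heavy atoms (4 carbon, 1 nitrogen; one five-membered non-aromatic ring with 1 hetero atom), on an aromatic carbon. Within the data shown here, only one measured step bears on this change, and it stayed within the scatter, so no shift beyond the scatter is expected in this assay, though the entering group is new to the series and the range is set wide. Compound 3 is expected to give 800 nM (250 nM to 2500 nM), an expected step of a 1.2-fold higher number from compound 2 to compound 3 (0.07 log units; within the scatter).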

Compound 3, half-maximal inhibitory concentration: 211 nM
Compound 3: middle estimate off by 3.8-fold (0.58 log units), on the high side, and the stated range ends above it.
By their numbers in this assay, from the lowest: compound 3; then compounds 2 and 1 (each within the scatter of the next).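

At the aromatic carbon next to the ring nitrogen and the ring oxygen, the amine now moves the number beyond the scatter in this assay: a 3.2-fold lower number from compound 2 to compound 3 (0.50 log units; beyond the scatter), and a 4.3-fold lower number from compound 1 to compound 3 (0.64 log units; beyond the scatter). This position therefore responds to the amine, although cyclohexylamino and pyrrolidin-1-yl alone gave no separable difference. No available evidence bears on the origin of this step.

From the compounds shown here alone, whether the step follows the added aromatic ring or its ring nitrogen remains open. An isoindolin-2-yl group, with carbon only in that aromatic ring, would separate the two.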